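The source may hold more compounds than are shown below. What is called first, only, known or untested is meant among the compounds shown, and "the series" means these compounds.

Compound 2 `COc1cc2nc(N3CCC(N4CCCC(CO)C4)CC3)nc(Nc3ccc(Cl)cc3)c2cc1OC` has the lower of the two numbers recorded so far in an in vitro functional assay on B300-19 cells for antagonist activity at C-C chemokine receptor type 4 (Homo sapiens), read by GTPgammaS binding; on this read-out lower numbers stand for stronger inhibition and higher numbers for weaker inhibition: compound 2 gives 19 nM, while compound 1 `COc1cc2nc(N3CCC(N4CCCC(CO)C4)CC3)nc(NCc3ccc(Cl)cc3)c2cc1OC` gives 87 nM. For the measured compounds named here, the only step between measured compounds, a 4.6-fold lower number from compound 1 to compound 2 (0.66 log units; beyond the scatter), came from putting 4-chlorophenyl in place of 4-chlorobenzyl on a nitrogen on an aromatic ring. Compound 3 `COc1cc2nc(N3CCC(N4CCCC(CO)C4)CC3)nc(-c3ccc(Cl)cc3)c2cc1OC` has not yet been measured in this assay. It differs from compound 2 by 4-chlorophenyl in place of (4-chlorophenyl)amino on an aromatic carbon. Going by the values given here, no measured step takes away the nitrogen that carries the 4-chlorophenyl, so the step from compound 1 to compound 2 bears on this change only loosely: it shows that what sits on that nitrogen shifts the number beyond the scatter, but says nothing about removing the nitrogen itself. The expected step, a 7.9-fold higher number from compound 2 to compound 3 (0.90 log units; beyond the scatter), therefore points to a higher number, held with wide uncertainty. The estimate for compound 3 in this assay is 150 nM, between 30 nM and 800 nM.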

Compound 3, half-maximal inhibitory concentration: > 1000 nM
Compound 3 ended at the assay's limit (the forecaster's own chance of this, stated with the estimate: 5%); middle value at least 6.6-fold (0.82 log units) away from the limit.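

For compound 3 the reading in this assay is a limit of the assay and not a number: the limit of > 1000 nM in this assay, at which 1 of the 3 values shown sits.

Taking out the nitrogen, so that the 4-chlorophenyl sits directly on the aromatic carbon, gives an at least 52-fold higher number from compound 2 to compound 3 (1.72 log units; beyond the scatter), which is larger than the change seen earlier when only the group on that nitrogen was altered. The comparison with the 4-chlorobenzyl amine points the same way, with an at least 11-fold higher number from compound 1 to compound 3 (1.06 log units; beyond the scatter), so at this position both compounds that keep the nitrogen have lower numbers than the compound without it.

On these data alone, what remains open is whether the nitrogen itself is needed or only a one-atom link between the core and the ring. An oxygen link, a methylene link or an N-methyl amine at this position would help to separate these possibilities.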